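The source may report more compounds than this note shows. Statements on the series, on what has been measured and on what is new or still open speak of the compounds shown alone.

Compound 3, with the structure `CC[C@@H]1C(=O)N(C)c2cnc(Nc3ccc(C(=O)NC4CCN(C)CC4)cc3OC)nc2N1CC(C)C`, gives the lowest number of the three measured compounds in a functional assay on MV4-11 cells (Homo sapiens) for cytotoxicity, read by CellTiter-Blue, with a stated time of 24 h; on this read-out higher numbers stand for weaker inhibition of growth and lower numbers for stronger inhibition of growth: compound 3 records 40 nM. Compound 1, built as `CC[C@@H]1C(=O)Nc2cnc(Nc3ccc(C(=O)NC4CCN(C)CC4)cc3OC)nc2N1C1CCCC1`, gives 219 nM, and compound 2, built as `CC[C@@H]1C(=O)N(Cc2ccccc2)c2cnc(Nc3ccc(C(=O)NC4CCN(C)CC4)cc3OC)nc2N1C1CCCC1`, gives 7280 nM. Compound 1 and compound 3 differ in two places at once, so their gap can only be read as what the two numbers show.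

Compound 4, with the structure `CC[C@@H]1C(=O)N(C)c2cnc(Nc3ccc(C(=O)NC4CCN(C)CC4)cc3OC)nc2N1Cc1cccc(Br)c1`, is not yet measured. It differs from compound 3 in one place: 3-bromophenyl in place of isopropyl on a saturated chain carbon bound to a nitrogen on an aromatic ring in a ring. For the measured compounds named here, only one measured step touches on a related kind of change, the one a 33-fold higher number from compound 1 to compound 2 (1.52 log units; beyond the scatter), where a benzyl group was added on an amide-type nitrogen in a ring. That step sits on a different nitrogen from the one involved here, so it bears on compound 4 only loosely; it does show that a bulky aromatic addition on this scaffold can cost a great deal of potency.

For compound 4 the expected outcome is therefore a weakening beyond the scatter, though smaller than the loss seen for compound 2, giving an expected step of a 3.8-fold higher number from compound 3 to compound 4 (0.57 log units; beyond the scatter). The estimate for compound 4 in this assay is 150 nM, within a range from 40 nM to 600 nM.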

Compound 4, concentration for 50% growth inhibition: 675 nM
Beside the measured number, compound 4's estimate is 4.5-fold (0.65 log units) below it, outside the stated range (above it).
By their numbers in this assay, from the lowest: compound 3; then compound 1; then compound 4; then compound 2.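

Replacing isopropyl with 3-bromophenyl on the saturated chain carbon gives a 17-fold higher number from compound 3 to compound 4 (1.23 log units; beyond the scatter) in this assay, so this place, and not only the amide-type nitrogen, responds strongly to what is attached there. Alongside a 33-fold higher number from compound 1 to compound 2 (1.52 log units; beyond the scatter), this gives two single changes at two different places, each bringing in a six-membered aromatic ring, and both move toward weaker inhibition of growth; neither step goes against this pattern, but two steps are a thin basis for it. Nothing available explains the size of the new loss.

The compounds shown do not separate the contribution of the aromatic ring from that of the bromine, and a 3-methoxybenzyl group in the same place would be one way to test whether the bromine matters. They also leave open whether a longer chain ending in an amine would retain the stronger inhibition of growth seen for compound 3 or lose it as compound 4 does.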